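Replacing an acyl thiophene by a sulfonyl thiophene

The source may hold more compounds than are shown below. What is called first, only, known or untested is meant among the compounds shown, and "the series" means these compounds.

Compound 2 `CCCCCCCCCCCCCCNC(=O)[C@@H](NC(=O)c1cccs1)[C@@H](C)O` gives 26500 nM in a functional assay on A-431 cells (Homo sapiens) for cytotoxicity, read by MTT assay, with a stated time of 48 h (a lower number here means a stronger inhibitor, a higher number a weaker inhibitor), the second highest of three numbers: compound 1 `CCCCCCCCNC(=O)[C@@H](NC(=O)c1cccs1)[C@@H](C)O` gives 32200 nM, and compound 3 `CCCCCCCCCCCCCCNC(=O)[C@@H](NC(=O)c1cc2ccccc2n1C)[C@@H](C)O` gives 13700 nM. The step of a 1.2-fold lower number from compound 1 to compound 2 (0.08 log units; within the scatter) and the step of a 1.9-fold lower number from compound 2 to compound 3 (0.29 log units; within the scatter) both stay within the scatter. Compound 4 `CCCCCCCCCCCCCCNC(=O)[C@@H](NS(=O)(=O)c1cccs1)[C@@H](C)O` carries (thiophen-2-yl)sulfonyl in place of (thiophen-2-yl)carbonyl on an amine nitrogen. Within the data shown here, no measured step changes the carbonyl to a sulfonyl on that nitrogen; the nearest precedent, the change of the group on the carbonyl carbon from compound 2 to compound 3, was within the scatter. Compound 4 is therefore expected to show no step beyond the scatter, with a 1.1-fold higher number from compound 2 to compound 4 (0.02 log units; within the scatter) as the estimate. Compound 4 is estimated at 28000 nM, within a range from 9000 nM to 85000 nM.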

Compound 4, half-maximal inhibitory concentration: 22000 nM
The estimate for compound 4 lay 1.3-fold (0.10 log units) above the measured number, within the range that was stated.
By their numbers in this assay, from the lowest: compounds 3, 4, 2 and 1 (each within the scatter of the next, the first and the last beyond it).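

In this assay, (thiophen-2-yl)sulfonyl in place of (thiophen-2-yl)carbonyl on the amine nitrogen gives a 1.2-fold lower number from compound 2 to compound 4 (0.08 log units; within the scatter) and so leaves the number unchanged within the scatter. The earlier steps shown here altered the chain and the group on the carbonyl carbon, whereas this one replaces the carbonyl itself. Nothing available explains this result. Still open, from the compounds shown here alone, is whether a methylene in place of the sulfonyl would also stay within the scatter, and whether the sulfonyl exchange would do so with the 1-methyl-1H-indol-2-yl group of compound 3.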